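Notes on a chloro-to-amino exchange, compound 2 to compound 3

The source may report more compounds than this note shows. Statements on the series, on what has been measured and on what is new or still open speak of the compounds shown alone.

Measured so far:
Compound 1 `Nc1nn(C(=O)Nc2ccc(Cc3ccccc3)cc2)c2ccccc12` gives 47400 nM in a functional assay on SNB-75 cells (Homo sapiens) for antiproliferative activity, read by sulforhodamine B assay, with a stated time of 48 h; on this read-out higher numbers stand for weaker inhibition of growth and lower numbers for stronger inhibition of growth.
Compound 2 `Nc1nn(C(=O)Nc2ccc(Cc3ccccc3)cc2)c2ccc(Cl)cc12` gives 32300 nM in this assay.

Compound 2 carries the lower of the two numbers, but the step of a 1.5-fold lower number from compound 1 to compound 2 (0.17 log units; within the scatter) lies within the scatter, so compound 1 and compound 2 cannot be separated on this read-out. Compound 3 `Nc1ccc2c(c1)c(N)nn2C(=O)Nc1ccc(Cc2ccccc2)cc1` differs from compound 2 in one place: amino in place of chloro on an aromatic carbon. Among the measured compounds shown here, no measured step exchanges chloro for amino, and the single step that is known, a 1.5-fold lower number from compound 1 to compound 2 (0.17 log units; within the scatter), stayed within the scatter. Nothing in the data therefore points to a move beyond the scatter in this assay in either direction. The expectation for compound 3 is a number close to that of compound 2, estimated at 38000 nM with a range of 14000 nM to 110000 nM. This estimate amounts to an expected step of a 1.2-fold higher number from compound 2 to compound 3 (0.07 log units; within the scatter), within the scatter.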

Compound 3, concentration for total growth inhibition: 31500 nM
Beside the measured number, compound 3's estimate is 1.2-fold (0.08 log units) above it; the measured number falls inside the stated range.
By their numbers in this assay, from the lowest: compounds 3, 2 and 1 (each within the scatter of the next).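

Chloro and amino on this aromatic carbon, meta to a fused ring and para to a fused ring, cannot be separated in this assay (a 1.0-fold lower number from compound 2 to compound 3 (0.01 log units; within the scatter)), even though amino brings 1 hydrogen-bond donor and 1 hydrogen-bond acceptor where chloro brings none. Amino also cannot be separated from hydrogen at this carbon (a 1.5-fold lower number from compound 1 to compound 3 (0.18 log units; within the scatter)), so hydrogen, chloro and amino now all sit within the scatter of one another, and the position has not yet shown a response to any exchange. No supporting data bear on this result.

On these data alone, whether a carboxylic acid, a methoxy group or a longer chain on this carbon would move the number beyond the scatter remains open. Also open, as far as these compounds go, is whether the same exchanges would read alike on the other aromatic carbons of this ring.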